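Benzyl versus aryl amides on the chromone acrylamide core

The source may hold more compounds than are shown below. What is called first, only, known or untested is meant among the compounds shown, and "the series" means these compounds.

Measured so far:
- compound 1 `COc1ccc2c(=O)c(/C=C/C(=O)Nc3cc(C)ccc3C)coc2c1`: 58400 nM
- compound 2 `Cc1ccc(CNC(=O)/C=C/c2coc3cc(O)ccc3c2=O)cc1`: > 100000 nM
- compound 3 `COc1ccc2c(=O)c(/C=C/C(=O)NCc3ccc(F)cc3)coc2c1`: > 100000 nM

Within the data shown here, in a functional assay on HeLa cells (Homo sapiens) for inhibition, read by MTT assay, with a stated time of 48 h (a lower number here means a stronger inhibitor, a higher number a weaker inhibitor), compound 1 gives 58400 nM, the only actual number in the set. For compound 2 the assay reports only the limit > 100000 nM. For compound 3 likewise only the limit > 100000 nM is recorded. Two of the three entries therefore sit at the same limit (the limit of > 100000 nM in this assay, at which 2 of the 3 values shown sit), and compound 1 is the single point from which a step can be measured.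

Among the measured compounds shown here, the one measured step with a single change is an at least 1.7-fold higher number from compound 1 to compound 3 (0.23 log units; that floor lies within the scatter); it runs toward the limit, so its true size is unknown and only its floor is given.

Compound 4 `COc1ccc2c(=O)c(/C=C/C(=O)NCc3ccc(C)cc3)coc2c1` is not yet measured. It differs from compound 1 by 4-methylbenzyl in place of 2,5-dimethylphenyl on an amide-type nitrogen. The change, like that to compound 3, replaces the aryl amide with a benzyl amide, and both benzyl-type compounds in the set, compound 2 and compound 3, sit at the limit. Compound 4 is therefore expected to give a weaker result than compound 1, with the step estimated as a 2.2-fold higher number from compound 1 to compound 4 (0.35 log units; beyond the scatter), and a fair chance that only a limit is returned. The estimated value for compound 4 is 130000 nM, within 50000 nM to 350000 nM.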

Compound 4, half-maximal inhibitory concentration: > 100000 nM
Compound 4 was reported as a limit; the forecaster's own chance of this, stated with the estimate: 65%; the middle value is on the limit's open side.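

In this assay, as far as these compounds go, 4-methylbenzyl in place of 2,5-dimethylphenyl on the amide-type nitrogen, a change that keeps the same atoms joined differently, gives an at least 1.7-fold higher number from compound 1 to compound 4 (0.23 log units; that floor lies within the scatter); this is a floor on the step, and its true size is unknown. With a methyl rather than a fluoro on the benzyl ring, the benzyl amide on this core still returns only a limit, and the steps among the limit compounds cannot be read. Compound 1, the only aryl amide shown, is the only compound with an actual number, and compounds 2, 3 and 4 all stop at the same limit: the limit of > 100000 nM in this assay, at which 3 of the 4 values shown sit.

From the compounds shown here alone, how far compounds 2, 3 and 4 lie past that limit stays open. Going by these compounds, it is also open whether an amine or a carboxylic acid on the benzyl ring, or a longer chain before the ring, would bring a value back within range.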